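From cyclopentyl to benzyl on the amide

The compounds below may be only part of what the source reports. "The series", "measured", "known", "first", "only" and "open" are said of these compounds alone.

In a functional assay on HUVEC cells (Homo sapiens) for antiproliferative activity (a lower number here means a stronger inhibitor, a higher number a weaker inhibitor), compound 1 (`CNC(=O)c1ccc(F)c(NCc2cnc(Nc3ccccn3)s2)c1`) gives 20 nM. Compound 2 (`O=C(NC1CCCC1)c1ccc(F)c(NCc2cnc(Nc3ccccn3)s2)c1`) has no number to stand on, and the entry for compound 2 reads "not determined" (no result reported). Compound 3 (`O=C(NCc1ccccc1)c1ccc(F)c(NCc2cnc(Nc3ccccn3)s2)c1`) differs from it in one place: benzyl in place of cyclopentyl on an amide-type nitrogen. For the measured compounds named here, no measured step shows what such a change does in this assay. Going by the values given here, the only guide is compound 1 at 20 nM, so a modest step towards weaker inhibition from that value is expected, with wide uncertainty. The estimate for compound 3 is 40 nM, with an expected range of 10 nM to 160 nM.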

Compound 3, half-maximal inhibitory concentration: 120 nM
Compound 3: the middle estimate sits 3.0-fold (0.48 log units) below what was measured; the range from low to high includes it.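

Placing phenyl on the methyl carbon of the amide keeps activity in this assay but weakens it, with a 6.0-fold higher number from compound 1 to compound 3 (0.78 log units; beyond the scatter) as the first measured change at this amide nitrogen. The change from cyclopentyl to benzyl itself cannot be read, since compound 2 has no value. Nothing here gives a cause for the loss. The compounds shown leave open how an ethyl or a longer chain on this nitrogen would compare, and whether a benzyl carrying an amine or a carboxylic acid would recover activity.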